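Swapping the Pyridine Arm for an Isobutyl Chain

This account rests on a few compounds, and the source may have more. Where it says the series, first, only, none or still open, it means among the compounds named here.

Measured compounds:
compound 1, `O=C(Cn1sc2ccccc2c1=O)NCc1ccccn1`, with 24%
compound 2, `O=c1c2ccccc2sn1-c1nc2ccccc2s1`, with 41.6%

Going by the values given here, in an assay on isolated protein for inhibition of histone acetyltransferase p300 (Homo sapiens), read by fluorescence, with a stated time of 10 min, tested at 50 uM (on this read-out higher numbers stand for more inhibition at the one concentration tested (going by the name of the read-out) and lower numbers for less inhibition), compound 1 gives 24%, the lowest of the two numbers measured so far. Compound 2 gives in this assay a higher 41.6%, and the gap between the two is beyond the usual scatter of this kind of measurement. Among the compounds with values here, the two compounds share a core but differ from each other in more than one place, so no single-point step between measured compounds is available as a guide.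

Compound 3, `CC(C)CNC(=O)Cn1sc2ccccc2c1=O`, differs from compound 1 in exactly one place: isopropyl in place of pyridin-2-yl on a saturated chain carbon bound to an amide-type nitrogen. Within the data shown here, no measured pair shows this kind of change, so the data do not say what size of step to expect in this assay, in which direction, or whether any step beyond the scatter should appear at all. Among the measured compounds shown here, the only anchor is the value of compound 1. On that basis compound 3 is expected to give about 20%, in a range from 5% to 38%. This estimate means a step of a number 4 percentage points lower from compound 1 to compound 3 (within the scatter), which is expected to stay within the scatter.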

Compound 3, a percentage reported as inhibition, at one concentration (the size of the read-out at that concentration, not a potency): 54.6%
Compound 3: the middle estimate sits 34.6 percentage points below what was measured; the whole stated range lies below it.
By their numbers in this assay, from the lowest: compound 1; then compound 2; then compound 3.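

Replacing pyridin-2-yl with isopropyl on a saturated chain carbon bound to an amide-type nitrogen gives, in this assay, a number 30.6 percentage points higher from compound 1 to compound 3 (beyond the scatter). Going by these compounds alone, this is the first comparison that changes only one place, and it shows that this position of the arm strongly affects the read-out, rather than being a part that can be changed with little consequence. It also shows that, on the shared core, the pyridine ring is not needed for inhibition at the one concentration tested, since isobutyl has no ring, fewer heavy atoms and no hydrogen-bond acceptor, yet compound 3 gives the higher number; no measurement at hand explains this difference.

The compounds shown do not separate the loss of the ring nitrogen from the loss of the whole aromatic ring or from the change in size; a benzyl group, which keeps a six-membered aromatic ring without that nitrogen, would help tell these apart. Going by these compounds, it also remains open how far the trend extends along the arm, for example to a longer chain such as n-pentyl, or to a cyclohexylmethyl group, which has a ring that is not aromatic.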